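The compounds below may be only part of what the source reports. "The series", "measured", "known", "first", "only" and "open" are said of these compounds alone.

Measured compounds and their solubility readings:
- compound 1, `Fc1ccc(/N=N/Nc2ccc(F)cc2F)c(F)c1`: 186000 nM
- compound 2, `CC(=O)N(/N=N/c1cccc(F)c1)c1cccc(F)c1`: 182000 nM
- compound 3, `COc1cc(/C=C/C(=O)N(/N=N/c2cc(C(F)(F)F)ccc2Cl)c2cc(C(F)(F)F)ccc2Cl)ccc1OC(C)=O`: 40300 nM

In a physicochemical assay for solubility (a lower number here means a less soluble compound, a higher number a more soluble compound), compound 3 stands lowest of the three numbers. Compound 2 sits nearest, with a higher number that lies beyond the scatter, and compound 1 sits furthest, also with a higher number beyond the scatter. Compound 1 and compound 2 themselves lie within the scatter of each other, so no order is read between them.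

Compound 4, `COc1cc(/C=C/C(=O)N(/N=N/c2cc(C(F)(F)F)ccc2Cl)c2cc(C(F)(F)F)ccc2Cl)cc(OC)c1`, differs from compound 3 in one place: 3,5-dimethoxyphenyl in place of 4-acetoxy-3-methoxyphenyl on a double-bonded chain carbon bound to a double-bonded chain carbon. Among the compounds with values here, no measured pair in this set shows a change of this kind, so there is no counted step to lean on; the two aryl groups are of similar size and the shared core is kept.

For compound 4 no step beyond the scatter is expected in this assay, in either direction. Compound 4 is estimated at 35000 nM, with a range of 12000 nM to 100000 nM. The step this estimate means, a 1.2-fold lower number from compound 3 to compound 4 (0.06 log units; within the scatter), is expected to stay within the scatter.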

Compound 4, solubility: 24100 nM
The estimate for compound 4 lay 1.5-fold (0.16 log units) above the measured number; measured number inside the range.
By their numbers in this assay, from the lowest: compounds 4 and 3 (each within the scatter of the next); then compounds 2 and 1 (each within the scatter of the next).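

In this assay, this position now has its first counted step, a 1.7-fold lower number from compound 3 to compound 4 (0.22 log units; within the scatter), so 3,5-dimethoxyphenyl in place of 4-acetoxy-3-methoxyphenyl on a double-bonded chain carbon bound to a double-bonded chain carbon does not separate the two compounds. The exchange keeps the shared core and the six-membered aromatic ring, while 3 hydrogen-bond acceptors leave and 2 enter, and with that count changed the two readings still cannot be ordered. No measured property of either group bears on this result.

Going by these compounds, what a dimethylamino group or a carboxylic acid on this aryl ring would give in this assay stays open. Also open, on these data alone, is whether the same exchange would give a step of this size on any other core.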